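The compounds below may be only part of what the source reports. "The series", "measured", "known", "first", "only" and "open" are said of these compounds alone.

Compound 1, `CCOC(=O)C1=Cc2ccccc2OC1(OCc1cc(-c2ccc(F)cc2F)no1)C(F)(F)F`, and compound 2, `CCOC(=O)C1=Cc2ccccc2OC1(OCc1cc(-c2ccc(C)cc2)no1)C(F)(F)F`, share one core and differ only in the aromatic group attached to the five-membered ring. In a functional assay on DU-145 cells (Homo sapiens) for inhibition, read by MTT assay, with a stated time of 24 h (on this read-out higher numbers stand for weaker inhibition and lower numbers for stronger inhibition), compound 1 gives > 150000 nM, which is a limit of the assay rather than a number. In this assay compound 2 gives > 150000 nM, likewise a limit and not a number. The step that the two limits leave unreadable from compound 1 to compound 2 therefore has no readable size. Indeed the limit of > 150000 nM in this assay, at which 2 of the 2 values shown sit, sums up the whole set: every value shown rests at that limit, so compound 2 stands where compound 1 does, with no number to place it more exactly. Compound 3, `CCOC(=O)C1=Cc2ccccc2OC1(OCc1cc(-c2ccc3ccccc3c2)no1)C(F)(F)F`, carries a further change at the same place: naphthalen-2-yl in place of 4-methylphenyl on an aromatic carbon. Within the data shown here, no measured step bears on this change, since the single step recorded is unreadable. Given that both values shown sit at the limit, the step that the limit leaves unreadable from compound 2 to compound 3 is expected to be none beyond the scatter, and the result is most likely another limit. Compound 3 is therefore estimated at 200000 nM, within a range from 100000 nM to 1000000 nM.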

Compound 3, half-maximal inhibitory concentration: 71800 nM
The estimate for compound 3 lay 2.8-fold (0.44 log units) above the measured number; the whole stated range lies above it.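

The new value shows that the group at this place, on an aromatic carbon of a five-membered aromatic ring with 1 nitrogen and 1 oxygen, can shift the read-out in this assay, which the first two compounds could not show. Naphthalen-2-yl, with 2 six-membered aromatic rings of carbon only, gives an at least 2.0-fold lower number from compound 2 to compound 3 (0.31 log units; beyond the scatter) and, measured against the 2,4-difluorophenyl group, an at least 2.0-fold lower number from compound 1 to compound 3 (0.31 log units; beyond the scatter). Compound 3 is thus the only compound of the three with a true number, and its two steps are lower bounds, while the step between the other two cannot be read, and the set remains dominated by one assay limit: the limit of > 150000 nM in this assay, at which 2 of the 3 values shown sit.

As far as these compounds go, with a single number, it stays open whether the lower value goes with the second aromatic ring itself or with the larger group as a whole, and how much lower the number is than those of compound 1 and compound 2. Also open, from the compounds shown here alone, is what an amine or a carboxylic acid on this aromatic group, or a longer chain in its place, would do to the number.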